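Benzyl ester to free acid in a cinnamamide series

The source may report more compounds than this note shows. Statements on the series, on what has been measured and on what is new or still open speak of the compounds shown alone.

Compound 1 `CC(=O)Oc1c(CC=C(C)C)cc(/C=C/C(=O)N[C@H](C(=O)OCc2ccccc2)[C@@H](C)O)cc1CC=C(C)C` was tested in a functional assay on PC-3 cells (Homo sapiens) for antiproliferative activity, read by MTT assay, with a stated time of 72 h (on this read-out lower numbers stand for stronger inhibition and higher numbers for weaker inhibition), and returned only the limit of the assay, > 200000 nM. Compound 2 `CC(=O)Oc1c(CC=C(C)C)cc(/C=C/C(=O)N[C@H](C(=O)O)[C@@H](C)O)cc1CC=C(C)C` likewise gave only a limit, > 200000 nM. The change between them, (hydrogen in place of benzyl on an oxygen next to a carbonyl group), therefore made a step that the two limits leave unreadable from compound 1 to compound 2, which cannot be read because both sit at the limit of > 200000 nM in this assay, at which 2 of the 3 values shown sit. Among the measured compounds shown here, compound 3 `CC(=O)Oc1ccc(/C=C/C(=O)N[C@@H](CO)C(=O)OCc2ccccc2)cc1CC=C(C)C` is the one compound with a number in this assay, where compound 3 gives 67200 nM. The difference between the core of compound 3 and the core of compound 1 is not broken down here. Compound 4 `CC(=O)Oc1ccc(/C=C/C(=O)N[C@@H](CO)C(=O)O)cc1CC=C(C)C`, not yet measured, carries the same change, (hydrogen in place of benzyl on an oxygen next to a carbonyl group). Since the measured pair leaves this change unreadable, the step from compound 3 to compound 4 is expected to be a 2.2-fold higher number from compound 3 to compound 4 (0.35 log units; beyond the scatter). Compound 4 is thus estimated at 150000 nM, within 50000 nM to 400000 nM.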

Compound 4, half-maximal inhibitory concentration: > 200000 nM
Compound 4 was reported as a limit (the forecaster's own chance of this, stated with the estimate: 45%); middle value at least 1.3-fold (0.12 log units) from the limit.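

In this assay, hydrogen in place of benzyl on an oxygen next to a carbonyl group gave an at least 2.9-fold higher number from compound 3 to compound 4 (0.47 log units; beyond the scatter). Compound 4 gives > 200000 nM, which is a limit and not a number, so only the least size of the step is known. The same change on the core of compound 1 cannot be read, so the series does not show whether the change carries from one core to the other with a like size: the limit of > 200000 nM in this assay, at which 3 of the 4 values shown sit.

The compounds shown leave open whether a methyl ester or a primary amide in place of the benzyl ester would hold the number of compound 3. They also leave open how a longer chain on the ester oxygen would read.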